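Sulfamoyl to carbamoylmethyl on an amine in a sulfone series

A few compounds are considered here, and "the series" means these few. Any claim that something is new, unique, unknown or untested is made for them only; others in the source may bear on it.

Measured so far:
compound 1, `NC[C@@H]1CCCc2cc(S(=O)(=O)c3cccc(O)c3)ccc21`, 0.251 nM
compound 2, `CN(C[C@@H]1CCCc2cc(S(=O)(=O)c3cccc(F)c3)ccc21)S(N)(=O)=O`, 3.98 nM

In an assay on isolated protein for displacement of a labelled ligand from 5-hydroxytryptamine receptor 6 (Homo sapiens) (on this read-out lower numbers stand for stronger inhibition and higher numbers for weaker inhibition), compound 2 gives the higher of the two numbers; compound 1 gives a lower one, and the gap between them lies beyond the scatter. Within the data shown here, no single-point step joins these two compounds, so only their values speak. Compound 3, `CN(CC(N)=O)C[C@@H]1CCCc2cc(S(=O)(=O)c3cccc(F)c3)ccc21`, has not been measured. It differs from compound 2 by carbamoylmethyl in place of sulfamoyl on an amine nitrogen. This exchange keeps the donor count while the acceptor count falls, and the expected step from compound 2 to compound 3 in this assay is a 1.3-fold higher number from compound 2 to compound 3 (0.10 log units; within the scatter), none beyond the scatter. Compound 3 is therefore estimated at 5 nM, in the range 1.5 nM to 16 nM.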

Compound 3, inhibition constant: 1.26 nM
For compound 3 the middle estimate is 4.0-fold (0.60 log units) above the measured one; measured number below the stated range.
By their numbers in this assay, from the lowest: compound 1; then compound 3; then compound 2.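

Among these compounds, the exchange gives a 3.2-fold lower number from compound 2 to compound 3 (0.50 log units; beyond the scatter) in this assay, the first step that can be read at this amine nitrogen. Sulfamoyl is therefore not required here for a low number, and carbamoylmethyl serves better in this pair, even as the acceptor count falls. Nothing measured here accounts for the step.

Going by these compounds, it remains open how a carboxylic acid or a longer chain ending in an amide would fare on this nitrogen. Whether the step would hold with the hydroxyl of compound 1 in place of fluorine also stays unanswered.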